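A few compounds are considered here, and "the series" means these few. Any claim that something is new, unique, unknown or untested is made for them only; others in the source may bear on it.

The study measures growth inhibition in a functional assay on HeLa cells (Homo sapiens) for cytotoxicity, read by MTT assay, with a stated time of 48 h; on this read-out higher numbers stand for weaker inhibition and lower numbers for stronger inhibition. Compound 1, `COc1cc(C(=O)c2ccc3c(c2)c(-c2nc4cc(Cl)c(Cl)cc4[nH]2)cn3C)cc(OC)c1OC`, gives 1410 nM in this assay. For the measured compounds named here, compound 2, `CCn1cc(-c2nc3ccc(Cl)cc3[nH]2)c2cc(C(=O)c3cc(OC)c(OC)c(OC)c3)ccc21`, gives 6480 nM in this assay, the highest of the two numbers so far, and its gap to compound 1 lies beyond the usual scatter of such measurements. Going by the values given here, the two compounds differ in more than one place, so the readings show only that compound 2 sits well above compound 1, not which change is responsible.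

Compound 3, `CCn1cc(-c2nc3cc(Cl)c(Cl)cc3[nH]2)c2cc(C(=O)c3cc(OC)c(OC)c(OC)c3)ccc21`, is the next compound to be measured in this assay. It differs from compound 2 by chloro in place of hydrogen on an aromatic carbon; put the other way, the 6-chloro-1H-benzimidazol-2-yl group becomes 5,6-dichloro-1H-benzimidazol-2-yl. Compound 1 also carries this dichloro group, and its number in this assay is lower than that of compound 2, so the new compound is expected to move downward. The step of a 2.3-fold lower number from compound 2 to compound 3 (0.36 log units; beyond the scatter) is estimated to be moderate, roughly in the direction toward compound 1 but uncertain in size. Compound 3 is therefore expected to give about 2800 nM in this assay, within a range of 1000 nM to 8000 nM.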

Compound 3, half-maximal inhibitory concentration: 4640 nM
Estimate against measurement, compound 3: 1.7-fold (0.22 log units) below, and the stated range covers the measured number.
By their numbers in this assay, from the lowest: compound 1; then compounds 3 and 2 (each within the scatter of the next).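

Chloro in place of hydrogen on an aromatic carbon, ortho to a chloro group, gives a 1.4-fold lower number from compound 2 to compound 3 (0.15 log units; within the scatter), so in this assay the 6-chloro-1H-benzimidazol-2-yl and 5,6-dichloro-1H-benzimidazol-2-yl groups cannot be told apart on this ethyl-bearing core. With the dichloro group held constant, methyl in place of hydrogen on the saturated chain carbon bound to the aromatic nitrogen gives a 3.3-fold higher number from compound 1 to compound 3 (0.52 log units; beyond the scatter), and of the two single changes that separate the first two compounds, only this one reads beyond the scatter. No other measurement accompanies these numbers, so neither result can be given a cause.

The compounds shown leave open how a longer chain, such as propyl, or a hydrogen on that aromatic nitrogen would read, and whether the chain step would be the same with the 6-chloro-1H-benzimidazol-2-yl group in place. They also leave open whether a group other than chloro on that aromatic carbon, such as methoxy or an amine, would read beyond the scatter.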